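The source may report more compounds than this note shows. Statements on the series, on what has been measured and on what is new or still open speak of the compounds shown alone.

Measured compounds:
- Compound 1, `CNC(=O)CCCCCCCn1nc(-c2ccc3oc(N)nc3c2)c2c(N)ncnc21`: in a functional assay on HeLa cells (Homo sapiens) for inhibition, read by MTT assay, with a stated time of 72 h (on this read-out lower numbers stand for stronger inhibition and higher numbers for weaker inhibition), compound 1 gives 12900 nM.
- Compound 2, `Nc1nc2cc(-c3nn(CC(=O)NO)c4ncnc(N)c34)ccc2o1`: in this assay compound 2 reaches only > 150000 nM, which is a limit of the assay and not a number.
- Compound 3, `Nc1nc2cc(-c3nn(CCCCCCCCC(=O)NO)c4ncnc(N)c34)ccc2o1`: in this assay compound 3 gives 10200 nM.

Among the two plain numbers, compound 1 holds the higher one, with compound 3 nearest at a 1.3-fold lower number from compound 1 to compound 3 (0.10 log units; within the scatter). The remaining value is a limit, described by the limit of > 150000 nM in this assay, at which 1 of the 3 values shown sits.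

Compound 4, `Nc1nc2cc(-c3nn(CCCCCCC(=O)NO)c4ncnc(N)c34)ccc2o1`, has not yet been measured in this assay. The change from compound 1 is hydroxycarbamoyl in place of (methylcarbamoyl)methyl on a saturated chain carbon, six bonds along the chain from an aromatic nitrogen.

Among the compounds with values here, two measured steps bear on this change. The step of an at least 11-fold higher number from compound 1 to compound 2 (1.06 log units; beyond the scatter) shows that a hydroxycarbamoyl group placed on the saturated chain carbon directly bound to the aromatic nitrogen loses nearly all inhibition. The step of a 1.3-fold lower number from compound 1 to compound 3 (0.10 log units; within the scatter) shows that the same group on a longer chain keeps inhibition essentially unchanged. Compound 4 places the hydroxycarbamoyl group six bonds along the chain, which lies between those two cases and much closer to compound 3 than to compound 2. The expected outcome is therefore a step within the scatter, a 1.6-fold lower number from compound 1 to compound 4 (0.21 log units; within the scatter), with no clear direction. On this basis compound 4 is estimated at 8000 nM, within the range 2000 nM to 40000 nM.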

Compound 4, half-maximal inhibitory concentration: 6410 nM
Compound 4: middle estimate off by 1.2-fold (0.10 log units), on the high side; the range from low to high includes it.
By their numbers in this assay, from the lowest: compounds 4, 3 and 1 (each within the scatter of the next). At a limit, above all of these: compound 2.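

In this assay, the change at this position gives a 2.0-fold lower number from compound 1 to compound 4 (0.30 log units; within the scatter), and the two compounds with the longer hydroxycarbamoyl chains compare as a 1.6-fold lower number from compound 3 to compound 4 (0.20 log units; within the scatter). Among these three compounds, neither the end group nor the chain length therefore gives a difference that can be told from the scatter, and compound 1 reads like the other two without carrying a hydroxycarbamoyl group at all. The one large difference lies at the other extreme of chain length, with an at least 23-fold lower number from compound 2 to compound 4 (1.36 log units; beyond the scatter), although compound 2 has a limit of the assay and not a number: the limit of > 150000 nM in this assay, at which 1 of the 4 values shown sits.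

The compounds shown leave open how short the chain can become before inhibition is lost, as a 3-(hydroxycarbamoyl)propyl chain on the same core would begin to show. They also leave open whether a carboxylic acid or an amine at the end of the chain of compound 4 would read the same as hydroxycarbamoyl, and so whether the end group matters at all at this chain length.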